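Isopropyl amide in place of the fluorophenyl amide

A few compounds are considered here, and "the series" means these few. Any claim that something is new, unique, unknown or untested is made for them only; others in the source may bear on it.

Compound 2 `COc1ccccc1C(=O)Nc1cccc(NC(=O)c2ccc(F)cc2)c1` is one of three amides built on a shared core. In an in vitro functional assay on HEK293-A cells for antagonist activity at metabotropic glutamate receptor 5 (Rattus norvegicus), read by calcium flux (on this read-out lower numbers stand for stronger inhibition and higher numbers for weaker inhibition), compound 2 gives only a limit of the assay, > 30000 nM. Compound 1 `COc1ccccc1C(=O)Nc1cccc(NC(=O)c2ccc(Cl)cc2)c1` likewise gives only a limit, > 30000 nM. Compound 3 `COc1ccccc1C(=O)Nc1cccc(NC(=O)c2cccc(C#N)c2)c1` gives 1800 nM. Among the compounds with values here, the step from compound 1 to compound 2 is a step that the two limits leave unreadable from compound 1 to compound 2, so the only readable steps are an at least 16-fold lower number from compound 2 to compound 3 (1.22 log units; beyond the scatter) and an at least 16-fold lower number from compound 1 to compound 3 (1.22 log units; beyond the scatter), both brought by the 3-cyanophenyl group. Compound 4 `COc1ccccc1C(=O)Nc1cccc(NC(=O)C(C)C)c1` differs from compound 2 by isopropyl in place of 4-fluorophenyl on a carbonyl carbon. Within the data shown here, no measured step covers an isopropyl group, and with two of the three values sitting at the limit of > 30000 nM in this assay, at which 2 of the 3 values shown sit, neither size nor direction of a step in this assay can be read from the measured compounds. Compound 4 is therefore expected to remain near the limit, estimated at 30000 nM (range 8000 nM to 100000 nM), an expected step of a number no higher from compound 2 to compound 4 (the limit leaves the size open).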

Compound 4, half-maximal inhibitory concentration: > 30000 nM
Compound 4 was reported as a limit; the forecaster's own chance of this, stated with the estimate: 75%; the middle value sits exactly at the limit.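

In this assay, isopropyl in place of 3-cyanophenyl on a carbonyl carbon brings an at least 16-fold higher number from compound 3 to compound 4 (1.22 log units; beyond the scatter), so a group with no ring does not keep the activity seen with 3-cyanophenyl. The steps among compound 1, compound 2 and compound 4 cannot be read, as all three values are limits. Limits now make up most of the series: the limit of > 30000 nM in this assay, at which 3 of the 4 values shown sit.

On these data alone, whether a longer chain, an amine or a carboxylic acid on this carbonyl carbon would give a readable value stays open. So does whether a nitrile on a group with no ring would do what it does in compound 3.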